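The compounds below may be only part of what the source reports. "The series", "measured", "known", "first", "only" and "open" are said of these compounds alone.

Working notes on the series. Compound 1 `O=c1c(Cl)c(CSC(=S)N2CCOCC2)oc2ccccc12` and compound 2 `O=c1c(CSC(=S)N2CCCCC2)coc2cc(Cl)ccc12` have both been run in a functional assay on HEp-2 cells (Homo sapiens) for antiproliferative activity, read by MTT assay, with a stated time of 72 h; a lower number here means a stronger inhibitor, a higher number a weaker inhibitor. In this assay compound 1 gives 9000 nM, the highest of the two numbers, and compound 2 gives 280 nM, a gap beyond the scatter; the two structures differ in more than one place, so the gap cannot be assigned to either change.

Compound 3 `O=c1c(Cl)c(CSC(=S)N2CCCCC2)oc2ccccc12` is not yet measured. It differs from compound 1 as follows: piperidin-1-yl in place of morpholin-4-yl on a thiocarbonyl carbon. Compound 2 also carries piperidin-1-yl, but with its chlorine elsewhere on the core, so its value is only a hint. For compound 3 a move towards a lower number is expected, of moderate size, a 2.3-fold lower number from compound 1 to compound 3 (0.35 log units; beyond the scatter), and not confidently beyond the scatter. The estimate for compound 3 in this assay is 4000 nM, with a range from 1000 nM to 12000 nM.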

Compound 3, half-maximal inhibitory concentration: 940 nM
The estimate for compound 3 lay 4.3-fold (0.63 log units) above the measured number; measured number below the stated range.
By their numbers in this assay, from the lowest: compound 2; then compound 3; then compound 1.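

In this assay, the step gives a 9.6-fold lower number from compound 1 to compound 3 (0.98 log units; beyond the scatter), so with the rest of compound 1 held fixed, the group on the thiocarbonyl carbon alone moves the number beyond the scatter. The earlier pair could not show this, as compound 1 and compound 2 differ in more than one place; here the change is only the ring oxygen of morpholin-4-yl giving way to the carbon of piperidin-1-yl. Nothing at hand bears on why this change shifts the number.

Still open, going by these compounds, is whether a smaller ring such as pyrrolidin-1-yl, an open-chain diethylamino group or a piperazin-1-yl ring would extend the step or reverse it. Also open, on these data alone, is whether the same exchange would give a step of similar size on the core of compound 2.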